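The source may report more compounds than this note shows. Statements on the series, on what has been measured and on what is new or still open speak of the compounds shown alone.

In a functional assay on MC-38 cells (Mus musculus) for antiproliferative activity, read by colorimetric assay and MTT assay (a higher number here means a weaker inhibitor, a lower number a stronger inhibitor), compound 1 (`O=[N+]([O-])c1ccc(S(=O)(=O)Nc2cccc3c(Cl)c[nH]c23)cc1`) gives 0.34 ug/mL, compound 2 (`N#Cc1ccc(S(=O)(=O)Nc2cccc3c(Cl)c[nH]c23)cc1`) gives 0.13 ug/mL and compound 3 (`N#Cc1ccc(S(=O)(=O)Nc2ccc(Cl)c3c(Cl)c[nH]c23)cc1`) gives 0.12 ug/mL. Compound 2 therefore stands level with compound 3, within the scatter, while compound 1 lies higher. Compound 4 (`Nc1ccc(S(=O)(=O)Nc2cccc3c(Cl)c[nH]c23)cc1`) carries amino in place of cyano on an aromatic carbon, para to a large group: amino in place of cyano on an aromatic carbon. For the measured compounds named here, the only measured change at that place is a 2.6-fold lower number from compound 1 to compound 2 (0.42 log units; beyond the scatter), which is modest, whereas a 1.1-fold lower number from compound 2 to compound 3 (0.03 log units; within the scatter) involves a chloro group instead. Going by the values given here, no amino compound has been measured, so this is a weak guide. Leaving cyano is expected to give a modest step to a higher number, estimated as a 3.1-fold higher number from compound 2 to compound 4 (0.49 log units; beyond the scatter). For compound 4 the expected value is 0.4 ug/mL, with an estimated range from 0.1 ug/mL to 1.6 ug/mL.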

Compound 4, half-maximal inhibitory concentration: 0.23 ug/mL
Compound 4: the middle estimate sits 1.7-fold (0.24 log units) above what was measured; measured number inside the range.
By their numbers in this assay, from the lowest: compounds 3, 2, 4 and 1 (each within the scatter of the next, the first and the last beyond it).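

In this assay, amino on this aromatic carbon, para to a large group, shows a 1.8-fold higher number from compound 2 to compound 4 (0.25 log units; within the scatter) and a 1.5-fold lower number from compound 1 to compound 4 (0.17 log units; within the scatter), so it stands level with both cyano and nitro. Those two are separated beyond the scatter, yet the amino group, which brings a hydrogen-bond donor that cyano lacks, fits within the scatter of each. Nothing available explains this result. As far as these compounds go, it remains open how a carboxylic acid or an acetamide would fare at this place. Also open, from the compounds shown here alone, is whether the extra chloro of compound 3 would leave the number of compound 4 unchanged.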